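The source may report more compounds than this note shows. Statements on the series, on what has been measured and on what is new or still open speak of the compounds shown alone.

Measured compounds:
- compound 1, `C=CC[C@H]1C[C@]2([C@H](C)Cc3ccc(OC)cc3)OCOC2=CC1=O`, with 81 nM in a functional assay on M14 cells (Homo sapiens) for antiproliferative activity, with a stated time of 72 h; on this read-out higher numbers stand for weaker inhibition and lower numbers for stronger inhibition
- compound 2, `C=CC[C@H]1C[C@]2([C@@H](C)Cc3ccc(OC)c(C)c3)OCOC2=CC1=O`, with 410 nM in this assay

Among the measured compounds shown here, of the two numbers measured so far, compound 2 carries the higher one, meaning the weaker inhibition of cell growth. Its nearest neighbour is compound 1, whose value is lower by a gap that lies beyond the usual scatter of repeated measurements. The two compounds differ from each other in more than one place, so their values can only be compared as they stand, not traced to a single change.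

Compound 3, `C=CC[C@H]1C[C@]2([C@@H](C)Cc3ccc(OC)c(C#N)c3)OCOC2=CC1=O`, has not yet been measured. It differs from compound 2 in one place: cyano in place of methyl on an aromatic carbon. For the measured compounds named here, no measured pair shows this exchange, so there is no step on which to base a firm expectation. The exchange keeps the group small and replaces one carbon-only substituent with a nitrogen-bearing one, and on the strength of what is known the expectation is for a change that stays near the scatter, in either direction.

Compound 3 is therefore estimated at 500 nM, with a plausible range from 150 nM to 1600 nM, which amounts to an expected step of a 1.2-fold higher number from compound 2 to compound 3 (0.09 log units; within the scatter).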

Compound 3, half-maximal inhibitory concentration: 180 nM
For compound 3 the middle estimate is 2.8-fold (0.44 log units) above the measured one, within the range that was stated.
By their numbers in this assay, from the lowest: compound 1; then compound 3; then compound 2.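

In this assay, cyano in place of methyl on the aromatic carbon ortho to a methoxy group gives a 2.3-fold lower number from compound 2 to compound 3 (0.36 log units; beyond the scatter), the first change among these compounds that can be traced to a single place. The step is modest, but it shows that this aromatic carbon is not indifferent to what it carries: a swap of one small group for another, with one more heavy atom and one hydrogen-bond acceptor in the count, goes with stronger inhibition of cell growth. No measurement at hand gives a reason for this step.

From the compounds shown here alone, with only methyl and cyano seen at this carbon, it stays open whether the gain belongs to cyano in particular or would also appear with a chlorine atom, an amide or an amine in the same spot. A single step also cannot say whether cyano would move the number the same way on the other stereochemical arrangement of the side chain, which compound 1 carries, or in cells other than these.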